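Adding a methoxy group to compound 1

A few compounds are considered here, and "the series" means these few. Any claim that something is new, unique, unknown or untested is made for them only; others in the source may bear on it.

Compound 1 `COc1cc(CCCNC(C)=O)ccc1OCc1ccccc1` is an amide carrying ether groups on its shared core. Among the compounds with values here, in an assay on CHO cells for displacement of a labelled ligand from melatonin receptor type 1B (Homo sapiens), read by scintillation counting, with a stated time of 60 min (a higher number here means a weaker inhibitor, a lower number a stronger inhibitor), compound 1 gives 69.3 nM, one of only two numbers measured so far. The other belongs to compound 2 `CCC(=O)NCCCc1ccc(OCc2ccccc2)c(OC)c1`, which in this assay gives 121 nM; the step from compound 1 to compound 2 is a 1.7-fold higher number from compound 1 to compound 2 (0.24 log units; within the scatter) and involves a methyl in place of a hydrogen on a saturated chain carbon bound to a carbonyl carbon, so the two compounds cannot be told apart on these numbers. Compound 3 `COc1cccc(COc2ccc(CCCNC(C)=O)cc2OC)c1` has not been measured yet. It differs from compound 1 by methoxy in place of hydrogen on an aromatic carbon, so that phenyl becomes 3-methoxyphenyl. Within the data shown here, no measured step touches this part of the molecule; the one known step, between compound 1 and compound 2, changes the amide end and stays within the scatter. With nothing pointing either way, compound 3 is expected to give a number near that of compound 1 in this assay, a step of a 1.2-fold higher number from compound 1 to compound 3 (0.06 log units; within the scatter) that is not expected to exceed the scatter. The estimate for compound 3 is 80 nM, with a range from 30 nM to 220 nM.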

Compound 3, inhibition constant: 105 nM
Compound 3: middle estimate off by 1.3-fold (0.12 log units), on the low side; low and high end bracket the measured number.
By their numbers in this assay, from the lowest: compounds 1, 3 and 2 (each within the scatter of the next).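

Turning phenyl into 3-methoxyphenyl is the first measured change at this end of the molecule, and in this assay it gives a 1.5-fold higher number from compound 1 to compound 3 (0.18 log units; within the scatter), so compound 1 and compound 3 cannot be told apart on these numbers. A methoxy group, with its 2 heavy atoms and 1 hydrogen-bond acceptor, can therefore sit on this aromatic carbon, meta to a large group, without a step beyond the scatter. Nothing measured here offers a reason for this result.

The compounds shown leave open whether the same holds for a methoxy group on the other carbons of the phenyl ring, and whether a different group on this carbon, such as a hydroxyl, an amine or a carboxylic acid, would move the number beyond the scatter. They also leave open whether 3-methoxyphenyl would give a similar result when combined with the amide end of compound 2, since that combination appears in none of the structures shown.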